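Swapping the Amide Aryl on a Weakly Antiproliferative Core

This account rests on a few compounds, and the source may have more. Where it says the series, first, only, none or still open, it means among the compounds named here.

The measured compounds and their values in a functional assay on PC-3 cells (Homo sapiens) for antiproliferative activity, read by MTT assay, with a stated time of 48 h; on this read-out higher numbers stand for weaker inhibition and lower numbers for stronger inhibition:
Compound 1, `O=C(Nc1cc(Sc2ncn[nH]2)c(O)c2ccccc12)c1ccc([N+](=O)[O-])cc1`, gives 53500 nM.
Compound 2, `Cn1nnnc1Sc1cc(NC(=O)c2ccc(Cl)cc2)c2ccccc2c1O`, reaches only the limit of the assay, > 100000 nM.
Compound 3, `O=C(/C=C/c1ccc(Cl)cc1)Nc1cc(Sc2ncn[nH]2)c(O)c2ccccc12`, likewise reaches only the limit, > 100000 nM.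

Going by the values given here, compound 1 is thus the one compound with an actual number; the other two sit at the limit of > 100000 nM in this assay, at which 2 of the 3 values shown sit. The account follows the step from compound 1 to compound 4, `Cc1cccc(C(=O)Nc2cc(Sc3ncn[nH]3)c(O)c3ccccc23)c1`, which is not yet measured. The change is 3-methylphenyl in place of 4-nitrophenyl on a carbonyl carbon.

Among the compounds with values here, one measured step bears on a change at the same place, the carbonyl carbon bound to the amide-type nitrogen: an at least 1.8-fold higher number from compound 1 to compound 3 (0.27 log units; that floor lies within the scatter). Within the data shown here, that step led to the limit rather than to a stronger value, and no measured step at this position shows a gain. Compound 2 carries a different change and tells nothing about this step. The 3-methylphenyl entering in compound 4 differs from the 2-(4-chlorophenyl)ethenyl that entered in compound 3, so the size of the step is open; an estimate near compound 1, with a wide range that reaches the limit, seems fitting.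

Compound 4 is therefore expected to give about 65000 nM in this assay, between 20000 nM and 200000 nM, which would mean an estimated step of a 1.2-fold higher number from compound 1 to compound 4 (0.08 log units; within the scatter).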

Compound 4, half-maximal inhibitory concentration: 59500 nM
For compound 4 the middle estimate is 1.1-fold (0.04 log units) above the measured one; measured number inside the range.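

In this assay, 3-methylphenyl in place of 4-nitrophenyl on the carbonyl carbon gives a 1.1-fold higher number from compound 1 to compound 4 (0.05 log units; within the scatter), so a group of carbon only, without the hydrogen-bond acceptors of 4-nitrophenyl, can stand at this place with no change beyond the scatter. Compound 1 no longer stands alone: compound 4 is a second compound in this series with an actual number, whereas the earlier step at this place ended at a limit. The comparison with the 2-(4-chlorophenyl)ethenyl amide gives an at least 1.6-fold lower number from compound 3 to compound 4 (0.22 log units; that floor lies within the scatter), and this can be read only as a floor, as compound 3 stands at a limit of the assay: the limit of > 100000 nM in this assay, at which 2 of the 4 values shown sit.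

From the compounds shown here alone, what an amine or a carboxylic acid on the phenyl ring, or a longer alkyl chain in its place, would do to the number in this assay stays open. Equally open, going by these compounds, is whether any group on this carbonyl carbon can give a step toward stronger inhibition beyond the scatter, as neither step read here does so.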